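Compound 4: a new group after three limits

The compounds below may be only part of what the source reports. "The series", "measured", "known", "first", "only" and "open" are said of these compounds alone.

In a functional assay on HeLa cells (Homo sapiens) for inhibition, read by CCK-8 assay, with a stated time of 48 h (a higher number here means a weaker inhibitor, a lower number a stronger inhibitor), compound 1 `Nc1ccc(Oc2ccccc2-c2ccc(S(=O)(=O)NCCNC(=O)Nc3ccc(Cl)cc3)s2)cc1` gives > 20000 nM, which is a limit and not a number. Compound 2 `COc1ccc(NC(=O)NCCNS(=O)(=O)c2sccc2-c2ccc(C)cc2Oc2ccc(O)c(O)c2)cc1` gives > 20000 nM, again a limit. Compound 3 `COc1ccc(NC(=S)NCCNS(=O)(=O)c2sccc2-c2ccc(C)cc2Oc2ccc(O)c(O)c2)cc1` gives > 20000 nM, also a limit, so it has no exact place on the scale. The whole set so far comes down to the limit of > 20000 nM in this assay, at which 3 of the 3 values shown sit.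

Compound 4 `Cc1ccc(-c2ccsc2S(=O)(=O)NCCNC(=O)Nc2ccc([N+](=O)[O-])cc2)c(Oc2ccc(O)c(O)c2)c1` differs from compound 3 in one place: a group of 12 heavy atoms (7 carbon, 2 nitrogen, 3 oxygen; one six-membered aromatic ring of carbon only) in place of a group of 11 heavy atoms (8 carbon, 1 nitrogen, 1 oxygen, 1 sulfur; one six-membered aromatic ring of carbon only), on an amine nitrogen. The entering group is (4-nitrophenyl)carbamoyl, on an amine nitrogen.

For the measured compounds named here, only one measured step bears on this change, a step that the two limits leave unreadable from compound 2 to compound 3. It offers no size to carry forward and no direction to follow. With so little to go on, the expected result in this assay is that little changes, and the assay may well report only a limit again. The expected step is a step that the limit leaves unreadable from compound 3 to compound 4, and its direction is uncertain. For compound 4 the estimated value is 25000 nM, with an expected range of 9000 nM to 60000 nM.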

Compound 4, half-maximal inhibitory concentration: > 20000 nM
Compound 4 was reported as a limit; the forecaster's own chance of this, stated with the estimate: 80%; the middle value is on the limit's open side.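

In this assay compound 4 gives > 20000 nM, a limit and not a number, so its steps from compound 2 and from compound 3 cannot be read. The compounds shown leave open whether exchanging these groups changes inhibition at all, since all share one ceiling: the limit of > 20000 nM in this assay, at which 4 of the 4 values shown sit.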